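The source may report more compounds than this note shows. Statements on the series, on what has been measured and on what is new or still open speak of the compounds shown alone.

Compound 1 `O=S(=O)(c1ccc(F)cc1)c1cnc2ccc(Cl)cc2c1-c1ccc(Cl)cc1` gives 0.2 mL/min in an ADME assay on microsomes from liver (Rattus norvegicus) for metabolic stability, tested at 2.5 uM (a lower number here means slower removal, a higher number faster removal of the compound), the lowest of the three numbers in hand. Compound 2 `O=S(=O)(c1ccc(F)cc1)c1cnc2cc(F)c(Cl)cc2c1-c1ccc(Cl)cc1` gives 0.34 mL/min and compound 3 `O=S(=O)(c1ccc(F)cc1)c1cnc2cc(F)ccc2c1-c1ccc(Cl)cc1` gives 0.89 mL/min. The step of a 1.7-fold higher number from compound 1 to compound 2 (0.23 log units; within the scatter) came with fluoro in place of hydrogen, and the step of a 2.6-fold higher number from compound 2 to compound 3 (0.42 log units; beyond the scatter) came with hydrogen in place of chloro. Compound 4 `O=S(=O)(c1ccc(F)cc1)c1cnc2ccc(F)cc2c1-c1ccc(Cl)cc1` differs from compound 1 by fluoro in place of chloro on an aromatic carbon. Neither measured step is this exact change; removal of the chloro in the step from compound 2 to compound 3 is the nearer case, so a modest rise is expected. The expected step is a 2.3-fold higher number from compound 1 to compound 4 (0.35 log units; beyond the scatter). Compound 4 is therefore estimated at 0.45 mL/min, with a range from 0.2 mL/min to 1 mL/min.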

Compound 4, intrinsic clearance in a liver preparation (reported as CLH), per the amount of preparation that the assay uses: 0.4 mL/min
The estimate for compound 4 lay 1.1-fold (0.05 log units) above the measured number; the range from low to high includes it.
By their numbers in this assay, from the lowest: compounds 1, 2 and 4 (each within the scatter of the next); then compound 3.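

With fluoro in place of chloro on this aromatic carbon, this assay shows a 2.0-fold higher number from compound 1 to compound 4 (0.30 log units; within the scatter) and so does not separate the two halogens here. Going by these compounds alone, the only earlier change at this carbon, hydrogen in place of chloro, was a 2.6-fold higher number from compound 2 to compound 3 (0.42 log units; beyond the scatter) and was made with a second fluoro on the same ring, so this is the first reading of a halogen swap alone. Nothing available explains either step. Still open, as far as these compounds go, is how a nitrile, a methoxy group or an amine on this carbon would read in this assay. Also open, from the compounds shown here alone, is whether hydrogen here, without that second fluoro, would give a step beyond the scatter.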